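From 2,4-dichlorophenyl to 2,6-dimethoxyphenyl on a carbonyl carbon

A few compounds are considered here, and "the series" means these few. Any claim that something is new, unique, unknown or untested is made for them only; others in the source may bear on it.

Of the compounds shown here, three sharing one core have been measured in an ADME assay on MT4 cells (Homo sapiens) for cytotoxicity, read by MTT assay; a higher number here means that more compound is tolerated, a lower number that less compound is tolerated. Compound 1 `Cc1ccc(N(C(=O)c2ccccc2C)C(=S)OCCN2C(=O)c3ccccc3C2=O)cc1` gives > 100000 nM, which is a limit of the assay and not a number. Compound 2 `Cc1ccc(N(C(=O)c2ccc([N+](=O)[O-])cc2)C(=S)OCCN2C(=O)c3ccccc3C2=O)cc1` gives 58000 nM, and compound 3 `Cc1ccc(N(C(=O)c2ccc(Cl)cc2Cl)C(=S)OCCN2C(=O)c3ccccc3C2=O)cc1` gives 49000 nM. These two numbers stand level, with a 1.2-fold lower number from compound 2 to compound 3 (0.07 log units; within the scatter).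

Compound 4 `COc1cccc(OC)c1C(=O)N(C(=S)OCCN1C(=O)c2ccccc2C1=O)c1ccc(C)cc1` keeps the core and changes one group: 2,6-dimethoxyphenyl in place of 2,4-dichlorophenyl on a carbonyl carbon. The measured steps all changed a group at this same place. Two of them start from the limit, so they give only floors: an at least 1.7-fold lower number from compound 1 to compound 2 (0.23 log units; that floor lies within the scatter), and an at least 2.0-fold lower number from compound 1 to compound 3 (0.30 log units; that floor lies within the scatter). For the measured compounds named here, the only step between two true numbers is the one between compound 2 and compound 3, and it stays within the scatter. A step beyond the scatter in this assay is therefore not expected here. The expected change is a 1.4-fold higher number from compound 3 to compound 4 (0.15 log units; within the scatter). For compound 4 the estimate is 70000 nM, with an expected range from 30000 nM to 100000 nM.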

Compound 4, half-maximal cytotoxic concentration: 36000 nM
Compound 4: middle estimate off by 1.9-fold (0.29 log units), on the high side; measured number inside the range.
By their numbers in this assay, from the lowest: compounds 4, 3 and 2 (each within the scatter of the next). At a limit, above all of these: compound 1.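

With 2,6-dimethoxyphenyl on the carbonyl carbon, this assay still separates none of the three groups that give true numbers: it shows a 1.4-fold lower number from compound 3 to compound 4 (0.13 log units; within the scatter) and a 1.6-fold lower number from compound 2 to compound 4 (0.21 log units; within the scatter). Even a group carrying hydrogen-bond acceptors, entering where 2,4-dichlorophenyl carried none, leaves the reading within the scatter, and the only step at this position that clears it is an at least 2.7-fold lower number from compound 1 to compound 4 (0.44 log units; beyond the scatter). That step is only a floor, as compound 1 stands at a limit of the assay and not at a number: the limit of > 100000 nM in this assay, at which 1 of the 4 values shown sits.

From the compounds shown here alone, how far compound 1 really lies from the other three remains open, so the 2-methylphenyl group cannot yet be given a size of effect. Also open, going by these compounds, is how this assay would read with an amine or a carboxylic acid on the phenyl ring at this position, or with a longer chain elsewhere in the shared core.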